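A few compounds are considered here, and "the series" means these few. Any claim that something is new, unique, unknown or untested is made for them only; others in the source may bear on it.

Among the compounds with values here, in a functional assay on MCF7 cells (Homo sapiens) for inhibition, read by fluorescence, with a stated time of 72 h (on this read-out higher numbers stand for weaker inhibition and lower numbers for stronger inhibition), compound 3 `CC(C)[C@H](N)COc1nc(NC(=N)N)c2ncn(C(C)C)c2n1` gives 3400 nM, the second highest of the three numbers so far. Compound 1 `CC[C@@H](CO)Nc1nc(NC(=N)N)c2ncn(C(C)C)c2n1` gives 1600 nM, and compound 2 `CC(C)[C@H](CO)Nc1nc(NC(=N)N)c2ncn(C(C)C)c2n1` gives 10500 nM.

Compound 4 `CC(C)[C@@H](CO)Nc1nc(NC(=N)N)c2ncn(C(C)C)c2n1` differs from compound 3 by one change, (1-(hydroxymethyl)-2-methylpropyl)amino in place of 2-amino-3-methylbutoxy on an aromatic carbon, between two ring nitrogen atoms. Within the data shown here, the entering group has the same name as the one in compound 2, but its defined stereocentre is drawn the opposite way, matching the arrangement in compound 1.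

Among the measured compounds shown here, three measured steps bear on this. The closest is a 3.1-fold lower number from compound 2 to compound 3 (0.49 log units; beyond the scatter), which exchanges the same two groups but starts from the other stereocentre form, so its size does not carry over directly. The step of a 6.6-fold higher number from compound 1 to compound 2 (0.82 log units; beyond the scatter) changes the chain and the stereocentre together, so the data do not separate the two. The step of a 2.1-fold higher number from compound 1 to compound 3 (0.33 log units; beyond the scatter) shows the distance from compound 3 to the nearest measured number. For the measured compounds named here, no measured pair isolates the stereocentre, so the estimate leans on compound 1 at 1600 nM and stays uncertain.

The expected result is a 1.7-fold lower number from compound 3 to compound 4 (0.23 log units; within the scatter), a small move towards a lower number. Compound 4 is estimated at 2000 nM, with an expected range of 700 nM to 6500 nM.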

Compound 4, half-maximal inhibitory concentration: 2100 nM
Estimate against measurement, compound 4: 1.1-fold (0.02 log units) below; low and high end bracket the measured number.
By their numbers in this assay, from the lowest: compounds 1, 4 and 3 (each within the scatter of the next, the first and the last beyond it); then compound 2.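

In this assay, within the data shown here, the pair of compound 2 and compound 4 gives the first reading of the stereocentre alone, and a 5.0-fold lower number from compound 2 to compound 4 (0.70 log units; beyond the scatter) shows that its configuration alone moves the number beyond the scatter; the only difference recorded for the pair lies at that stereocentre: the fact that one of compounds 2 and 4 is drawn with a defined configuration and the other without, at the place where they differ.

With the configuration of compound 4, the extra methyl in place of hydrogen on the saturated chain carbon gives a 1.3-fold higher number from compound 1 to compound 4 (0.12 log units; within the scatter) and so no readable change, which means that a 6.6-fold higher number from compound 1 to compound 2 (0.82 log units; beyond the scatter) no longer reads as an effect of the longer branched chain alone, and the stereocentre accounts for much of its size. The exchange of 2-amino-3-methylbutoxy for (1-(hydroxymethyl)-2-methylpropyl)amino also reads differently by configuration: a 1.6-fold lower number from compound 3 to compound 4 (0.21 log units; within the scatter) stays within the scatter, while a 3.1-fold lower number from compound 2 to compound 3 (0.49 log units; beyond the scatter) lies beyond it.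

The compounds shown leave open whether the stereocentre matters as much in the 1-(hydroxymethyl)propyl chain or in 2-amino-3-methylbutoxy, as neither appears here in its opposite configuration. Also open, as far as these compounds go, is how a phenyl group on that chain carbon, or an amine in place of the hydroxyl of the hydroxymethyl group, would fare in this assay on the shared core.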